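The source may hold more compounds than are shown below. What is called first, only, known or untested is meant among the compounds shown, and "the series" means these compounds.

Measured in a functional assay on MCF7 cells (Homo sapiens) for antiproliferative activity, read by MTT assay, with a stated time of 72 h; on this read-out lower numbers stand for stronger inhibition and higher numbers for weaker inhibition:

- Compound 1 `CC1=CC[C@H]2[C@@H]1CC=C(C)[C@@H](CCC1=C(C)CC[C@@H]3OC(C)(C)[C@@H](O)CC[C@@]13C)C2(C)C`: > 50000 nM (a limit)
- Compound 2 `CC1=CC[C@H]2[C@H](CC[C@]2(C)O)C(C)(C)[C@@H]1CC[C@H]1[C@]2(C)CC[C@H](OC(=O)CCC(=O)O)C(C)(C)O[C@H]2CC[C@@]1(C)O`: > 50000 nM (a limit)
- Compound 3 `CC1=CC[C@H]2[C@H](CC[C@]2(C)O)C(C)(C)[C@@H]1CC[C@H]1[C@]2(C)CC/C(=N/OC(=O)c3ccccc3)C(C)(C)O[C@H]2CC[C@@]1(C)O`: 25600 nM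

Compound 2 has no exact number, and its result of > 50000 nM is only a limit. Among the measured compounds shown here, compound 1 also stops at a limit, so the series so far shows (the limit of > 50000 nM in this assay, at which 2 of the 3 values shown sit).

Compound 4 `CC1=CC[C@H]2[C@H](CC[C@]2(C)O)C(C)(C)[C@@H]1CC[C@H]1[C@]2(C)CC[C@H](OC(=O)c3ccc(F)cc3)C(C)(C)O[C@H]2CC[C@@]1(C)O` differs from compound 2 in one place, with 4-fluorophenyl in place of 2-carboxyethyl on a carbonyl carbon. For the measured compounds named here, no measured pair shows this change directly. Going by the values given here, the only guide is compound 3, which gives 25600 nM and also carries an aromatic ring on a carbonyl carbon. A modest gain in inhibition is therefore expected in this assay, not a large one. The expected size of this change is an at least 2.2-fold lower number from compound 2 to compound 4 (0.35 log units; beyond the scatter), and the assay may still report only a limit. Compound 4 is estimated at 22000 nM, with an expected range from 7000 nM to 60000 nM.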

Compound 4, half-maximal inhibitory concentration: 33500 nM
Beside the measured number, compound 4's estimate is 1.5-fold (0.18 log units) below it; the measured number falls inside the stated range.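

With 4-fluorophenyl on a carbonyl carbon, compound 4 gives 33500 nM in this assay, which shows that an exact number can be read with an ester of this kind in place of the 2-carboxyethyl ester. Compound 2 gives > 50000 nM, which is a limit of the assay and not a number. The change therefore reads only as an at least 1.4-fold lower number from compound 2 to compound 4 (0.17 log units; that floor lies within the scatter), and its true size stays open, with the floor set by a limit that also holds for another compound in the series: the limit of > 50000 nM in this assay, at which 2 of the 4 values shown sit.

The compounds shown leave open whether the fluorine plays any part, which a plain phenyl or a 4-methoxyphenyl on the same carbonyl carbon would test. They also leave open whether a longer alkyl chain or an amine at this place would give a different number.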